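Enol in place of the aminobenzylidene arm of compound 2

The compounds below may be only part of what the source reports. "The series", "measured", "known", "first", "only" and "open" are said of these compounds alone.

The series shares a dienone core, varied at the exocyclic carbon and on the aryl rings. In a functional assay on A549 cells (Homo sapiens) for inhibition, read by sulforhodamine B assay, with a stated time of 48 h (a higher number here means a weaker inhibitor of growth, a lower number a stronger inhibitor of growth), compound 1 `COc1ccc(/C=C/C(=O)C(=Cc2ccc(O)c(OC)c2)C(=O)/C=C/c2ccc(OC)cc2)cc1` gives 1640 nM. Compound 2 `COc1ccc(/C=C/C(=O)C(=Cc2ccc(N(C)C)cc2)C(=O)/C=C/c2ccc(OC)c(OC)c2)cc1OC` gives 2620 nM in this assay; compound 2 and compound 1 lie within the usual scatter of each other, so no order between them can be read. Compound 3 `COc1cc(/C=C/C(=O)C(=CO)C(=O)/C=C/c2ccc(OC(C)=O)c(OC)c2)ccc1OC(C)=O` is reported in this assay only as a limit, > 25000 nM, not as a number.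

Compound 4 `COc1ccc(/C=C/C(=O)C(=CO)C(=O)/C=C/c2ccc(OC)c(OC)c2)cc1OC` is not yet measured. It differs from compound 2 in one place: hydroxy in place of 4-(dimethylamino)phenyl on a double-bonded chain carbon bound to a double-bonded chain carbon. Compound 3 also carries this hydroxy and sits at the limit of > 25000 nM in this assay, at which 1 of the 3 values shown sits, so a step beyond the scatter towards weaker growth inhibition is expected from compound 2 to compound 4, with a real chance that this assay again returns only a limit. The expected step is a 7.6-fold higher number from compound 2 to compound 4 (0.88 log units; beyond the scatter). Compound 4 is estimated to give 20000 nM in this assay, with a range from 6000 nM to 60000 nM. Whether the acetoxy groups of compound 3 contribute to its limit cannot be separated here; compound 4 keeps the methoxy groups of compound 2 and will test that directly.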

Compound 4, concentration for 50% growth inhibition: > 25000 nM
Compound 4 gave a limit, no number; the forecaster's own chance of this, stated with the estimate: 55%; middle value at least 1.2-fold (0.09 log units) away from the limit.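

Within the data shown here, at the double-bonded chain carbon bound to a double-bonded chain carbon, replacing 4-(dimethylamino)phenyl with hydroxy gives in this assay an at least 9.5-fold higher number from compound 2 to compound 4 (0.97 log units; beyond the scatter) as the first single-place change that can be read. With the methoxy groups of compound 2 kept, compound 4 gives > 25000 nM as a limit, not a number, so acetoxy groups are not required for a compound with hydroxy at this position to reach that limit. Both compounds shown with hydroxy at this position sit at the same reported limit: the limit of > 25000 nM in this assay, at which 2 of the 4 values shown sit.

Because both are limits, compound 3 and compound 4 cannot be ordered, and the acetoxy and methoxy groups cannot be compared beyond that limit. From the compounds shown here alone, whether the step follows from losing the 4-(dimethylamino)phenyl group or from introducing hydroxy remains open, and an unsubstituted phenyl ring or a methyl group on the same carbon would be needed to tell these apart.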